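Para-substituent changes on the aryl urea ACAT series

A few compounds are considered here, and "the series" means these few. Any claim that something is new, unique, unknown or untested is made for them only; others in the source may bear on it.

Going by the values given here, compound 2 `CC(C)c1ccc(NC(=O)NCC2(c3ccccc3)CCCCC2)cc1` gives 1500 nM in an assay on microsomes from intestine for inhibition of acyl-CoA:cholesterol acyltransferase (Oryctolagus cuniculus) (on this read-out lower numbers stand for stronger inhibition and higher numbers for weaker inhibition), the lowest of the two numbers so far. Compound 1 `Cc1ccc(NC(=O)NCC2(c3ccccc3)CCCCC2)cc1` gives 4500 nM. Among the compounds with values here, the only measured step, a 3.0-fold lower number from compound 1 to compound 2 (0.48 log units; beyond the scatter), shows a modest gain from a larger alkyl group. Compound 3 `CCOC(=O)c1ccc(NC(=O)NCC2(c3ccccc3)CCCCC2)cc1` carries ethoxycarbonyl in place of isopropyl on an aromatic carbon. Within the data shown here, no measured step swaps an alkyl for an ester, so the alkyl-size trend offers little guidance; a change of similar size in either direction, or none beyond the scatter, is expected for a 1.7-fold higher number from compound 2 to compound 3 (0.22 log units; within the scatter). Compound 3 is therefore estimated at 2500 nM in this assay, between 800 nM and 8000 nM.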

Compound 3, half-maximal inhibitory concentration: 6100 nM
For compound 3 the middle estimate is 2.4-fold (0.39 log units) below the measured one, and the stated range covers the measured number.
By their numbers in this assay, from the lowest: compound 2; then compounds 1 and 3 (each within the scatter of the next).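

At this position, on an aromatic carbon para to a large group, the number does not follow group size: ethoxycarbonyl, with 5 heavy atoms against 3 for isopropyl, gives a 4.1-fold higher number from compound 2 to compound 3 (0.61 log units; beyond the scatter). Set against the smaller methyl, the ester does not separate (a 1.4-fold higher number from compound 1 to compound 3 (0.13 log units; within the scatter)), so isopropyl alone stands apart among the three groups. No measurement shown here explains this difference.

Open, going by these compounds, is whether branched alkyl is what favours this position, which a tert-butyl or a straight propyl chain would test. A carboxylic acid or a primary amide in place of the ester would show whether the carbonyl group itself carries the change.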